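The compounds below may be only part of what the source reports. "The series", "measured", "known", "first", "only" and "open" are said of these compounds alone.

Of the compounds shown here, three have so far been measured in an ADME assay on the whole organism (Macaca fascicularis) for metabolic stability, read by LC-MS, using cassette dosing, at a dose of 1 mg/kg by the oral route; a higher number here means that the compound lasts longer, a lower number that the compound disappears faster. Compound 1 `CCCCN(c1nc2ccccc2o1)[C@H](C)c1ccc(-c2ccccc2-c2nnn[nH]2)cc1` gives 3.2 h. Compound 2 `CCCCN(c1nc2c(C(=O)O)cccc2o1)[C@H](C)c1ccc(-c2ccccc2-c2nnn[nH]2)cc1` gives 3.7 h. Compound 3 `CCCCN(c1nc2c(C(=O)NS(C)(=O)=O)cccc2o1)[C@H](C)c1ccc(-c2ccccc2-c2nnn[nH]2)cc1` gives 2.7 h. Compound 3 has the lowest of the three numbers, but the distances to it are small: a 1.2-fold lower number from compound 1 to compound 3 (0.07 log units; within the scatter) and a 1.4-fold lower number from compound 2 to compound 3 (0.14 log units; within the scatter) both lie within the scatter, so the three compounds cannot be told apart in this assay.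

Compound 4 `CCCCN(c1nc2c(NC(C)=O)cccc2o1)[C@H](C)c1ccc(-c2ccccc2-c2nnn[nH]2)cc1` has not yet been measured. It differs from compound 3 in one place: acetamido in place of (methylsulfonyl)carbamoyl on an aromatic carbon. The measured steps that bear on this change all alter what sits at this same part of the shared core, and none of them moved the number beyond the scatter: a 1.2-fold higher number from compound 1 to compound 2 (0.06 log units; within the scatter), a 1.2-fold lower number from compound 1 to compound 3 (0.07 log units; within the scatter) and a 1.4-fold lower number from compound 2 to compound 3 (0.14 log units; within the scatter). No step beyond the scatter is therefore expected in this assay, in either direction. Compound 4 is expected to give about 3 h, with a range from 1.8 h to 5 h. The expected step is a 1.1-fold higher number from compound 3 to compound 4 (0.05 log units; within the scatter), which stays within the scatter.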

Compound 4, half-life: 2.2 h
Compound 4: the middle estimate sits 1.4-fold (0.13 log units) above what was measured, within the range that was stated.
By their numbers in this assay, from the lowest: compounds 4, 3, 1 and 2 (each within the scatter of the next).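

In this assay, acetamido is joined to the aromatic carbon through its nitrogen, unlike carboxy and (methylsulfonyl)carbamoyl, which are joined through a carbonyl carbon, yet this change of attachment moves no number beyond the scatter (a 1.2-fold lower number from compound 3 to compound 4 (0.09 log units; within the scatter)). The same holds for the steps from the other two compounds (a 1.7-fold lower number from compound 2 to compound 4 (0.23 log units; within the scatter); a 1.5-fold lower number from compound 1 to compound 4 (0.16 log units; within the scatter)), so all four groups at this position, hydrogen included, remain indistinguishable in this assay. Nothing available explains why these numbers stay so close.

Still open, from the compounds shown here alone, is whether an amine, a hydroxy group or a longer chain on the amide at this aromatic carbon would also stay within the scatter. The compounds shown also cannot tell whether a change elsewhere on the shared core would matter more than changes at this position.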